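This account rests on a few compounds, and the source may have more. Where it says the series, first, only, none or still open, it means among the compounds named here.

Measured so far:
- compound 1, `CC(c1ccc(-c2ccsc2)nc1)n1ccnc1`: 151 nM
- compound 2, `c1cn(C(c2ccc(-c3ccsc3)nc2)C2CC2)cn1`: 31 nM
- compound 3, `CC(c1ccc(-c2cccc3ccccc23)nc1)n1ccnc1`: 273 nM

All three were tested in an in vitro assay on V79MZh cells for inhibition of cytochrome P450 11B2, mitochondrial (Homo sapiens); on this read-out higher numbers stand for weaker inhibition and lower numbers for stronger inhibition. Compound 1 and compound 2 share one core and differ in one place: cyclopropyl in place of methyl on a saturated chain carbon bound to an aromatic carbon and an aromatic nitrogen. That single change gave a 4.9-fold lower number from compound 1 to compound 2 (0.69 log units; beyond the scatter). Compound 3 carries a different core from compound 1; how the two cores differ is not broken down here. In this assay compound 3 gives 273 nM, and its number stands within the scatter of the number for compound 1, so no order between the two can be read from them.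

Compound 4, `c1ccc2c(-c3ccc(C(C4CC4)n4ccnc4)cn3)cccc2c1`, has not yet been measured. It is related to compound 3 exactly as compound 2 is to compound 1: cyclopropyl in place of methyl on a saturated chain carbon bound to an aromatic carbon and an aromatic nitrogen. The place is described in the same words in both pairs, so this is the same change made on a second core. Among the compounds with values here, only one earlier instance of the change is available, so the expectation rests on that one step alone, and it is not known whether the second core answers the change in the same way.

For compound 4 the expected step from compound 3 is a 4.2-fold lower number from compound 3 to compound 4 (0.62 log units; beyond the scatter), because compound 1 to compound 2 showed a 4.9-fold lower number from compound 1 to compound 2 (0.69 log units; beyond the scatter). On that basis compound 4 is estimated to give 65 nM in this assay, with a range from 25 nM to 170 nM to allow for the change landing differently on the core of compound 3.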

Compound 4, half-maximal inhibitory concentration: 220 nM
The estimate for compound 4 lay 3.4-fold (0.53 log units) below the measured number, and the stated range ends below it.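

In this assay, putting cyclopropyl in place of methyl on the core of compound 3 gave a 1.2-fold lower number from compound 3 to compound 4 (0.09 log units; within the scatter), so on this core the change produces no difference that can be read from the numbers. The same change therefore did not carry over from one core to the other with the same size: the same change on two cores in this assay, a 4.9-fold lower number (0.69 log units; beyond the scatter) from compound 1 to compound 2 and a 1.2-fold lower number (0.09 log units; within the scatter) from compound 3 to compound 4, 3.9-fold (0.59 log units) apart, beyond the scatter of two such steps. Within the data shown here, this shows that the step seen on the core of compound 1 cannot simply be transferred, but with only two cores it does not show which part of the cores sets the difference, nor how the change would behave on a third core.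

From the compounds shown here alone, it remains open whether ethyl, isopropyl, cyclobutyl or a longer chain on a saturated chain carbon bound to an aromatic carbon and an aromatic nitrogen would follow the pattern of the core of compound 1 or that of the core of compound 3. Also open, going by these compounds, is whether cores lying between these two in structure would answer the change in cyclopropyl strongly, weakly or not at all.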